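The compounds below may be only part of what the source reports. "The series", "measured", "known", "first", "only" and "open" are said of these compounds alone.

Compound 1 `N[C@H]1CC[C@H](Nc2c(C(=O)NCc3ccc(F)cc3)nc(N3CCCCC3)c3cccnc23)CC1`: "not determined" (no result reported)
Compound 2 `NCCCNc1c(C(=O)NCc2ccc(F)cc2)ncc2cccnc12`: > 10000 nM
Compound 3 `O=C(NCCCNc1c(C(=O)NCc2ccc(F)cc2)nc(Br)c2cccnc12)c1ccccc1`: > 10000 nM

All three were examined in a functional assay on HT-29 cells (Homo sapiens) for cytotoxicity, read by MTT assay, with a stated time of 72 h; a lower number here means a stronger inhibitor, a higher number a weaker inhibitor. For compound 1 no single number exists; its entry reads "not determined" (no result reported). Compound 2 reaches only a limit of the assay, > 10000 nM. Compound 3 likewise stops at a limit, > 10000 nM. So the limit of > 10000 nM in this assay, at which 2 of the 3 values shown sit, accounts for two of the three results shown.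

Compound 4 `N[C@H]1CC[C@H](Nc2c(C(=O)NCc3ccc(F)cc3)nc(N3CCCCS3(=O)=O)c3cccnc23)CC1` is compound 1 with a group of 8 heavy atoms (4 carbon, 1 nitrogen, 2 oxygen, 1 sulfur; one six-membered non-aromatic ring with 2 hetero atoms) in place of a group of 6 heavy atoms (5 carbon, 1 nitrogen; one six-membered non-aromatic ring with 1 hetero atom), on an aromatic carbon. Within the data shown here, no step between measured compounds is available, so the size of the step from compound 1 to compound 4 in this assay cannot be read from the numbers; because the limit of > 10000 nM in this assay, at which 2 of the 3 values shown sit, is all the shared core has delivered so far, he expects no shift beyond the scatter and most likely another limit. Compound 4 is estimated at 8000 nM, with a range of 1000 nM to 30000 nM.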

Compound 4, half-maximal inhibitory concentration: > 10000 nM
Compound 4: a limit, no number (the forecaster's own chance of this, stated with the estimate: 60%); at least 1.2-fold (0.09 log units) between middle value and limit.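

No step can be read between compound 1 and compound 4: compound 1 has no single number, and compound 4 gives only a limit. The compounds shown leave open how any change on the shared core would register in this assay, where the results end at one value: the limit of > 10000 nM in this assay, at which 3 of the 4 values shown sit.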